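Halogen exchange on the anilide ring: chloro to fluoro

This account rests on a few compounds, and the source may have more. Where it says the series, first, only, none or still open, it means among the compounds named here.

Compound 2 `CCC(C(=O)Nc1cccc(Cl)c1)N1C(=O)CCC1=O` is the ring-chlorinated analogue of compound 1 `CCC(C(=O)Nc1ccccc1)N1C(=O)CCC1=O`. In a functional assay on the whole organism (strain Swiss) with Mus musculus as the target, in the maximal electroshock model (a lower number here means that less compound is needed, a higher number that more compound is needed for the effect), compound 1 gives 116 mg/kg. For compound 2 this assay reports only a limit of > 130 mg/kg, not a number. Compound 2 therefore stands at the top of the measured range, as recorded in the limit of > 130 mg/kg in this assay, at which 1 of the 2 values shown sits, and the step of an at least 1.1-fold higher number from compound 1 to compound 2 (0.04 log units; that floor lies within the scatter) has a floor that lies within the scatter, so no resolvable shift is established. Compound 3 `CCC(C(=O)Nc1cccc(F)c1)N1C(=O)CCC1=O` differs from compound 2 by fluoro in place of chloro on an aromatic carbon. Within the data shown here, the only measured step that bears on this exchange is an at least 1.1-fold higher number from compound 1 to compound 2 (0.04 log units; that floor lies within the scatter), a halogen entering on an aromatic carbon without a detectable effect; a second halogen swap at that carbon is expected to leave this assay essentially unchanged. The expected step is a number no higher from compound 2 to compound 3 (the limit leaves the size open), none beyond the scatter. For compound 3 the estimated value is 130 mg/kg, within a range of 75 mg/kg to 225 mg/kg.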

Compound 3, dose for half-maximal effect: 121 mg/kg
Compound 3: middle estimate off by 1.1-fold (0.03 log units), on the high side; the range from low to high includes it.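

Among these compounds, compound 3 puts the first actual number on a halogen at this carbon: in this assay compound 3 gives 121 mg/kg. Against the unsubstituted anilide the reading is a 1.0-fold higher number from compound 1 to compound 3 (0.02 log units; within the scatter), so fluoro in place of hydrogen leaves no resolvable shift here, which the chloro step could not settle with only a floor. The halogen exchange itself reads as an at least 1.0-fold lower number from compound 2 to compound 3 (0.03 log units; that floor lies within the scatter), a floor and not a size: the limit of > 130 mg/kg in this assay, at which 1 of the 3 values shown sits.

On these data alone, whether a different kind of group at this carbon, such as an amine or a methoxy group, would move the result beyond the scatter remains open. Also open, as far as these compounds go, is whether either halogen would behave the same way on another carbon of the ring, or alongside a longer chain on the shared core.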